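Notes on hydroxycyclohexyl ureas: step from compound 3 to compound 4

The source may hold more compounds than are shown below. What is called first, only, known or untested is meant among the compounds shown, and "the series" means these compounds.

Measured so far:
compound 1 `CN(C(=O)NCCCOc1ccc2nc(O)ccc2c1)[C@@H]1CCCC[C@H]1O`: 18%
compound 2 `O=C(NCCCOc1ccc2nc(O)ccc2c1)N(C1CCCCCCC1)[C@H]1CCCC[C@@H]1O`: 100%
compound 3 `O=C(NCCCOc1ccc2nc(O)ccc2c1)N(C1CC1)[C@@H]1CCC[C@@H](O)C1`: 20%

In a functional assay on the whole organism for inhibition, with Mus musculus as the target, at a dose of 30 mg/kg by the oral route (on this read-out higher numbers stand for more inhibition at the one dose given (going by the name of the read-out) and lower numbers for less inhibition), compound 3 gives 20%, the second highest of the three numbers. Compound 1 sits within the scatter of it, so no order between the two can be stated. Compound 2, with its 100%, lies far beyond the scatter above compound 3.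

Compound 4 `CCCCO[C@H]1CCCC[C@@H]1N(C(=O)NCCCOc1ccc2nc(O)ccc2c1)C1CC1` is not yet measured. It differs from compound 3 in one place: 2-butoxycyclohexyl in place of 3-hydroxycyclohexyl on an amide-type nitrogen. Within the data shown here, no measured pair shows this change, so its size is unknown. Compound 4 is expected to give 40% (range 10% to 80%), a step of a number 20 percentage points higher from compound 3 to compound 4 (beyond the scatter) that is expected to be modest and upward, but may well stay within the scatter.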

Compound 4, a percentage reported as inhibition, in the whole organism at one dose (the size of the read-out at that dose, not a potency): 33%
For compound 4 the middle estimate is 7 percentage points above the measured one; low and high end bracket the measured number.
By their numbers in this assay, from the lowest: compounds 1 and 3 (each within the scatter of the next); then compound 4; then compound 2.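

In this assay, the swap on the amide-type nitrogen gives a number 13 percentage points higher from compound 3 to compound 4 (beyond the scatter), so this position accepts 2-butoxycyclohexyl, a group with no hydrogen-bond donor, without loss of inhibition at this dose. Nothing available gives a reason for this step.

The change alters both the place of the oxygen on the ring and hydroxy versus butoxy, and the compounds shown do not separate the two. On these data alone, how 2-hydroxycyclohexyl with the same cyclopropyl partner, a 2-aminocyclohexyl group or a longer chain such as hexyloxy would read here remains open.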